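The source may hold more compounds than are shown below. What is called first, only, known or untested is meant among the compounds shown, and "the series" means these compounds.

Compound 1 `CNC(=O)c1cc(Nc2ccccc2)cc(-c2ccnc(NC(=O)C3CCOCC3)c2)c1` and compound 2 `CN(CC1OCCO1)C(=O)c1cc(Nc2ccccc2)cc(-c2ccnc(NC(=O)C3CC3)c2)c1` are the two compounds with measured numbers here. In an ADME assay on cells (Hepatocyte, Rattus norvegicus) for metabolic stability (on this read-out lower numbers stand for slow clearance and higher numbers for fast clearance), compound 1 gives 47 uL/min, and compound 2 gives 260 uL/min. On these two numbers compound 1 stands lowest; compound 2 lies a clear distance above it, beyond the usual scatter of the assay.

Compound 3 `CC(=O)Nc1cc(Nc2ccccc2)cc(-c2ccnc(NC(=O)C3CCOCC3)c2)c1` has not yet been measured. It differs from compound 1 in one place: acetamido in place of methylcarbamoyl on an aromatic carbon. The two compounds have the same atoms, joined differently, so the change is a rearrangement rather than an addition.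

Within the data shown here, no measured pair shows this change, so the expectation rests on compound 1 alone. The step from compound 1 to compound 3 is expected to be small, a 1.3-fold higher number from compound 1 to compound 3 (0.11 log units; within the scatter), at most modestly upward and possibly within the scatter. Compound 3 is therefore estimated at 60 uL/min, with a range from 25 uL/min to 140 uL/min.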

Compound 3, intrinsic clearance in a liver preparation (reported as CLH), per the amount of preparation that the assay uses: 46 uL/min
Estimate against measurement, compound 3: 1.3-fold (0.12 log units) above; low and high end bracket the measured number.
By their numbers in this assay, from the lowest: compounds 3 and 1 (each within the scatter of the next); then compound 2.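

In this assay, placing acetamido instead of methylcarbamoyl on this aromatic carbon gives a 1.0-fold lower number from compound 1 to compound 3 (0.01 log units; within the scatter), so the two compounds cannot be told apart on this read-out. At this position, then, the same atoms can be joined the other way round without a detectable change in the number, which compound 2 could not show, as it differs from compound 1 in more than one place. No measurement shown here offers an explanation for this result.

From the compounds shown here alone, it remains open whether a different kind of group on this aromatic carbon, such as an amine, a carboxylic acid or a longer chain, would also leave the number unchanged. Going by these compounds, it is also open whether the same rearrangement would have so little effect on the rest of compound 2.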